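Dichlorophenyl sulfonamide on a dinitroaniline core

The source may hold more compounds than are shown below. What is called first, only, known or untested is meant among the compounds shown, and "the series" means these compounds.

Measured so far:
Compound 1, `CCCN(CCC)c1c([N+](=O)[O-])cc(S(=O)(=O)Nc2ccc(OC)cc2)cc1[N+](=O)[O-]`, gives 31000 nM in a functional assay on PC-3 cells (Mus musculus) for cytotoxicity against PC-3 (Homo sapiens); a lower number here means a stronger inhibitor, a higher number a weaker inhibitor.
Compound 2, `CCCN(CCC)c1c([N+](=O)[O-])cc(S(=O)(=O)Nc2cccc(OC)c2)cc1[N+](=O)[O-]`, gives 36000 nM in this assay.
Compound 3, `CCCN(CCC)c1c([N+](=O)[O-])cc(S(=O)(=O)Nc2cccc(Cl)c2)cc1[N+](=O)[O-]`, gives 18000 nM in this assay.

Compound 2 holds the highest of the three numbers, though all three lie close together: the step of a 1.2-fold higher number from compound 1 to compound 2 (0.06 log units; within the scatter) is within the scatter, and so is the step of a 2.0-fold lower number from compound 2 to compound 3 (0.30 log units; within the scatter).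

Compound 4, `CCCN(CCC)c1c([N+](=O)[O-])cc(S(=O)(=O)Nc2ccc(Cl)c(Cl)c2)cc1[N+](=O)[O-]`, has not yet been measured. It differs from compound 2 in one place: 3,4-dichlorophenyl in place of 3-methoxyphenyl on a sulfonamide nitrogen.

For the measured compounds named here, two measured steps bear on this change. The step of a 2.0-fold lower number from compound 2 to compound 3 (0.30 log units; within the scatter) swaps methoxy for chloro on the aromatic carbon, and the step of a 1.7-fold lower number from compound 1 to compound 3 (0.24 log units; within the scatter) also ends at the chlorophenyl sulfonamide. Both point toward a somewhat lower number for a chlorinated ring, but neither leaves the scatter. Going by the values given here, compound 4 carries a second chlorine that no measured compound shows, so the record gives no direct guide for it.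

For compound 4 a step of about a 2.4-fold lower number from compound 2 to compound 4 (0.38 log units; beyond the scatter) is therefore expected, a modest lowering that might just reach beyond the scatter. The estimate for compound 4 is 15000 nM, with a range from 6000 nM to 40000 nM.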

Compound 4, half-maximal inhibitory concentration: 15000 nM
For compound 4 middle estimate and measured number coincide at the digits printed, within the range that was stated.
By their numbers in this assay, from the lowest: compounds 4, 3, 1 and 2 (each within the scatter of the next, the first and the last beyond it).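

For the compounds shown here, putting 3,4-dichlorophenyl on the sulfonamide nitrogen gives the first steps that lie beyond the scatter, both modest: a 2.4-fold lower number from compound 2 to compound 4 (0.38 log units; beyond the scatter) and a 2.1-fold lower number from compound 1 to compound 4 (0.32 log units; beyond the scatter). The second chlorine alone cannot be told apart from no change, since chloro in place of hydrogen on the aromatic carbon gives a 1.2-fold lower number from compound 3 to compound 4 (0.08 log units; within the scatter). Nothing available here explains these steps.

The compounds shown leave open whether a trifluoromethyl group or a carboxylic acid on this aromatic ring would shift the number further than the two chlorines do. They also leave open how the number would respond to a longer chain in place of the propyl groups on the amine nitrogen of the shared core.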